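This account rests on a few compounds, and the source may have more. Where it says the series, first, only, none or still open, it means among the compounds named here.

Permeability notes on the series. Within the data shown here, compound 2 `NC/C=C/CN(C[C@H]1Cc2ncccc2CN1)[C@H]1CCCc2cccnc21` gives 15 nm/s in an ADME assay for permeability, using PAMPA, with a stated time of 4 h, at pH 7.4; a higher number here means that the compound crosses the layer faster, a lower number that the compound crosses the layer more slowly; among the three numbers so far it stands second highest. Compound 1 `NCCCCN(C[C@H]1Cc2cccnc2CN1)[C@H]1CCCc2cccnc21` gives 6 nm/s in this assay, a lower number beyond the scatter, and compound 3 `CN(CCCCN(C[C@H]1Cc2ncccc2CN1)[C@H]1CCCc2cccnc21)C1CCC(F)(F)CC1` gives 310 nm/s, a far higher number beyond the scatter. Compound 4 `c1cnc2c(c1)CN[C@@H](CN(CCCCNC1COC1)[C@H]1CCCc3cccnc31)C2` is not yet measured. It differs from compound 2 thus: a group of 8 heavy atoms (6 carbon, 1 nitrogen, 1 oxygen; one four-membered non-aromatic ring with 1 hetero atom) in place of a group of 4 heavy atoms (3 carbon, 1 nitrogen; no ring), on a saturated chain carbon bound to an amine nitrogen. Among the measured compounds shown here, no measured pair isolates this change. The expected step in this assay, from compound 2 to compound 4, is a moderate rise, a 2.7-fold higher number from compound 2 to compound 4 (0.43 log units; beyond the scatter), expected because compound 3 gives 310 nm/s with a larger group on that chain, while the group entering here is smaller than that of compound 3. Compound 4 is estimated at 40 nm/s, with a range from 10 nm/s to 150 nm/s.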

Compound 4, apparent permeability: 300 nm/s
Beside the measured number, compound 4's estimate is 7.5-fold (0.88 log units) below it; the measured number lies above the stated range.
By their numbers in this assay, from the lowest: compound 1; then compound 2; then compounds 4 and 3 (each within the scatter of the next).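

On the saturated chain carbon bound to an amine nitrogen, a group with a four-membered non-aromatic ring in place of 3-aminoprop-1-en-1-yl goes with a large rise in this assay (a 20-fold higher number from compound 2 to compound 4 (1.30 log units; beyond the scatter)). Further along the chain, the four-membered ring and the larger six-membered carbon ring with two fluorines are not separated (a 1.0-fold lower number from compound 3 to compound 4 (0.01 log units; within the scatter)). No measured property accounts for either step.

Open, from the compounds shown here alone, is whether a cyclobutyl group, with carbon in place of the ring oxygen, would read the same. Also open, going by these compounds, is how a simple dimethylamine or a longer chain would read at this place.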